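Benzyl ether variation: from compound 3 to compound 4

A few compounds are considered here, and "the series" means these few. Any claim that something is new, unique, unknown or untested is made for them only; others in the source may bear on it.

Measured so far in a functional assay on CHO-K1 cells for antagonist activity at prostaglandin E2 receptor EP1 subtype (Homo sapiens), read by FLIPR; a higher number here means a weaker inhibitor, a lower number a stronger inhibitor:
compound 1 `Cc1cc(C(=O)O)nn1Cc1cc(Br)ccc1OCc1ccc(F)cc1F`, 2.63 nM
compound 2 `Cc1cc(C(=O)O)nn1Cc1cc(Br)ccc1OCc1ccc(Cl)cc1`, 8.71 nM
compound 3 `Cc1cc(C(=O)O)nn1Cc1cc(Br)ccc1OCc1ccc(F)cc1`, 11.8 nM

Compound 3 gives the highest number of the three; compound 2 lies within the scatter of it, while a 4.5-fold higher number from compound 1 to compound 3 (0.65 log units; beyond the scatter) is modest and beyond the scatter. Compound 4 `COc1ccccc1COc1ccc(Br)cc1Cn1nc(C(=O)O)cc1C` differs from compound 3 by 2-methoxyphenyl in place of 4-fluorophenyl on a saturated chain carbon bound to an oxygen on an aromatic ring. Within the data shown here, no measured step alters the benzyl ether in this way: a 1.4-fold higher number from compound 2 to compound 3 (0.13 log units; within the scatter) swaps one halogen for another and stays within the scatter, whereas a 3.3-fold higher number from compound 1 to compound 2 (0.52 log units; beyond the scatter) and a 4.5-fold higher number from compound 1 to compound 3 (0.65 log units; beyond the scatter) remove a fluoro and are modest. Among the measured compounds shown here, the entering group has no counterpart among the measured compounds, so the step of a 1.2-fold higher number from compound 3 to compound 4 (0.07 log units; within the scatter) is expected to be small, direction uncertain, with wide bounds. Compound 4 is estimated at 14 nM, range 3 nM to 70 nM.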

Compound 4, inhibition constant: 69.2 nM
The estimate for compound 4 lay 4.9-fold (0.69 log units) below the measured number, within the range that was stated.
By their numbers in this assay, from the lowest: compound 1; then compounds 2 and 3 (each within the scatter of the next); then compound 4.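

Putting 2-methoxyphenyl on a saturated chain carbon bound to an oxygen on an aromatic ring gives a weaker inhibitor than each halogenated compound: a 5.9-fold higher number from compound 3 to compound 4 (0.77 log units; beyond the scatter), a 7.9-fold higher number from compound 2 to compound 4 (0.90 log units; beyond the scatter) and a 26-fold higher number from compound 1 to compound 4 (1.42 log units; beyond the scatter), the last being large. This place therefore does not accept every substituted phenyl alike, and the only non-halogenated phenyl shown gives the highest number. Nothing available explains this loss.

From the compounds shown here alone, it remains open whether the loss follows from the methoxy group or from the absence of halogen. How a hydroxyl or an amine would read on this phenyl is also unresolved.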